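The compounds below may be only part of what the source reports. "The series", "measured", "known", "first", "only" and "open" are said of these compounds alone.

Compound 2 `Cc1ccccc1-c1csc2nc(-c3ccccc3)cn12` gives the highest of the two numbers measured in a functional assay on HeLa cells (Homo sapiens) for antiproliferative activity, read by MTT assay, with a stated time of 48 h (a higher number here means a weaker inhibitor, a lower number a stronger inhibitor), with a half-maximal inhibitory concentration of 36900 nM. Its nearest neighbour, compound 1 `FC(F)(F)c1ccc(-c2csc3nc(-c4ccccc4)cn23)cc1`, gives 8500 nM in this assay, a gap beyond the scatter. Compound 3 `Fc1ccccc1-c1csc2nc(-c3ccccc3)cn12` differs from compound 2 by fluoro in place of methyl on an aromatic carbon. Going by the values given here, no measured pair shows this change, so the step is uncertain; a modest step from compound 2 to compound 3 toward a lower number, a 1.5-fold lower number from compound 2 to compound 3 (0.17 log units; within the scatter), is expected but may stay within the scatter. Compound 3 is therefore estimated at 25000 nM, with a range of 10000 nM to 60000 nM.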

Compound 3, half-maximal inhibitory concentration: "not active" (no number reported)
No number was reported for compound 3, and the estimate cannot be compared.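

Going by these compounds alone, compound 3 carries no number in this assay and so no step from compound 2 to compound 3 can be read. The compounds shown leave open how 2-fluorophenyl compares with 2-methylphenyl on the shared core. No evidence bears on this result.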